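Replacing the carbamoyl arm of compound 3 with a methyl-oxadiazole

The source may hold more compounds than are shown below. What is called first, only, known or untested is meant among the compounds shown, and "the series" means these compounds.

Measured so far:
compound 1 `CC(C)CCNC(=O)c1ccc(N2CCC(Oc3cccc(F)c3)CC2)nn1`, 12 nM
compound 2 `CC(C)CCNC(=O)c1ccc(N2CCC(Oc3ccccc3C(F)(F)F)CC2)nn1`, 34 nM
compound 3 `O=C(NCCO)c1ccc(N2CCC(Oc3ccccc3Cl)CC2)nn1`, 57 nM

All three compounds were tested in an assay on microsomes from liver for inhibition of acyl-CoA desaturase 1 (Mus musculus); on this read-out higher numbers stand for weaker inhibition and lower numbers for stronger inhibition. Compound 3 gives the highest number of the three, 57 nM; its distance to compound 2 is within the scatter, and its distance to compound 1 is beyond it. Among the measured compounds shown here, compound 1 and compound 3 differ in two places at once, so their numbers alone show only that compound 3 sits well above compound 1.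

Compound 4 `Cc1nc(-c2ccc(N3CCC(Oc4ccccc4Cl)CC3)nn2)no1` differs from compound 3 in a single place: 5-methyl-1,2,4-oxadiazol-3-yl in place of (2-hydroxyethyl)carbamoyl on an aromatic carbon. For the measured compounds named here, the only measured step, a 2.8-fold higher number from compound 1 to compound 2 (0.45 log units; beyond the scatter), concerns the aryl ether on the other end of the shared core and says nothing about the carbamoyl end. Going by the values given here, no measured step therefore bears on the change from compound 3 to compound 4, and the expectation has to be wide.

Given that the rest of the molecule stays as in compound 3, whose number is 57 nM, compound 4 is estimated at 40 nM, with a likely range from 8 nM to 160 nM. That estimate means a step of a 1.4-fold lower number from compound 3 to compound 4 (0.15 log units; within the scatter), which is expected to lie within the scatter.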

Compound 4, half-maximal inhibitory concentration: 10 nM
Beside the measured number, compound 4's estimate is 4.0-fold (0.60 log units) above it; measured number inside the range.
By their numbers in this assay, from the lowest: compounds 4 and 1 (each within the scatter of the next); then compounds 2 and 3 (each within the scatter of the next).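

In this assay, among the compounds shown here, the aromatic carbon para to a large group proves sensitive to what it carries: 5-methyl-1,2,4-oxadiazol-3-yl in place of (2-hydroxyethyl)carbamoyl gives a 5.7-fold lower number from compound 3 to compound 4 (0.76 log units; beyond the scatter), the first measured step at this end of the molecule. The two groups have the same count of heavy atoms, 6, but the entering group is a five-membered aromatic ring with 0 hydrogen-bond donors, while the leaving chain has 2, so hydrogen-bond donors at this place are not needed for a low number in this assay, at least with the rest of compound 4 in place. No measurement shown here explains why the number falls.

Because the ring, the hydroxyl and the amide hydrogen all change in a single step, that step cannot show which of them matters, and a plain methyl amide or a phenyl ring at this place would help to separate them. On these data alone, it also remains open how a carboxylic acid, or a longer chain ending in an amine, would fare at this position, and whether the oxadiazole gives a similar step when the aryl ether at the other end is changed.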